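Taking the acetyl off compound 2: expected step

The source may report more compounds than this note shows. Statements on the series, on what has been measured and on what is new or still open speak of the compounds shown alone.

Measured so far:
compound 1 `CCOCc1c(C)coc1-c1ccc2c(c1OC)CCCC2(C)C` gives 21.6 uM
compound 2 `COc1c(-c2occ(C)c2COC(C)=O)ccc2c1CCCC2(C)C` gives 25.4 uM

In a functional assay on KB cells (Homo sapiens) for cytotoxicity, read by sulforhodamine B assay, with a stated time of 3 days (a higher number here means that more compound is needed for the effect, a lower number that less compound is needed), compound 2 gives 25.4 uM and stands level with compound 1 within the scatter. Compound 3 `COc1c(-c2occ(C)c2CO)ccc2c1CCCC2(C)C` differs from compound 2 by hydrogen in place of acetyl on an oxygen on a saturated carbon with hydrogen in place of acetyl on an oxygen on a saturated carbon. Among the measured compounds shown here, the only measured step bearing on this is a 1.2-fold higher number from compound 1 to compound 2 (0.07 log units; within the scatter) with acetyl in place of ethyl on an oxygen on a saturated carbon, so only a small change is expected. The step expected is a 1.0-fold lower number from compound 2 to compound 3 (0.01 log units; within the scatter) and nothing beyond the scatter. For compound 3 the expected value is 25 uM within an estimated range of 12 uM to 50 uM overall.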

Compound 3, concentration for half-maximal effect: 25.3 uM
Compound 3: middle estimate off by 1.0-fold (0.01 log units), on the low side, and the stated range covers the measured number.
By their numbers in this assay, from the lowest: compounds 1, 3 and 2 (each within the scatter of the next).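

In this assay the free hydroxymethyl stands level with both substituted forms, with a 1.0-fold lower number from compound 2 to compound 3 (0.00 log units; within the scatter) and a 1.2-fold higher number from compound 1 to compound 3 (0.07 log units; within the scatter) as the steps to it. Hydrogen on this oxygen on a saturated carbon therefore reads like acetyl and ethyl, whereas the earlier pair covered only acetyl and ethyl. Nothing available accounts for this flat reading. Going by these compounds, whether an amine, a carboxylic acid or a longer chain at this place would shift the number stays open. So does whether changes elsewhere on the shared core would do so.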